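Phenoxy for phenyl on the dimethylphenyl core

A few compounds are considered here, and "the series" means these few. Any claim that something is new, unique, unknown or untested is made for them only; others in the source may bear on it.

All values come from a functional assay on the whole organism (strain Wistar) for inhibition, with Rattus norvegicus as the target, with stated times of 30 min and 3 h, at a dose of 20 mg/kg by the oral route; a higher number here means more inhibition at the dose given (going by the name of the read-out), a lower number less inhibition.
Compound 1 `Cc1ccc(C(=O)CCc2nnc(Cc3ccccc3)o2)cc1` gives 51.9%.
Compound 2 `Cc1ccc(C(=O)CCc2nnc(COc3ccccc3)o2)cc1` gives 42%.
Compound 3 `Cc1ccc(C(=O)CCc2nnc(Cc3ccccc3)o2)c(C)c1` gives 50%.

From compound 1 to compound 2 the change is phenoxy in place of phenyl on a saturated chain carbon bound to an aromatic carbon, and the step is a number 9.9 percentage points lower from compound 1 to compound 2 (within the scatter). The two cores differ by methyl in place of hydrogen on an aromatic carbon, with a step of a number 1.9 percentage points lower from compound 1 to compound 3 (within the scatter).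

Compound 4 `Cc1ccc(C(=O)CCc2nnc(COc3ccccc3)o2)c(C)c1` is not yet measured. It differs from compound 3 by phenoxy in place of phenyl on a saturated chain carbon bound to an aromatic carbon, the same change seen between compound 1 and compound 2, at the same place. Going by the values given here, for compound 4 the expected step is a number 10 percentage points lower from compound 3 to compound 4 (within the scatter), a size taken from the earlier pair because a number 9.9 percentage points lower from compound 1 to compound 2 (within the scatter) is the only measurement of this change here; its transfer onto the dimethyl core rests on a single precedent. Compound 4 is therefore estimated at 40%, expected to lie between 28% and 52%.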

Compound 4, a percentage reported as inhibition, in the whole organism at one dose (the size of the read-out at that dose, not a potency): 45.7%
Beside the measured number, compound 4's estimate is 5.7 percentage points below it, within the range that was stated.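

In this assay, the step for phenoxy in place of phenyl on the second core is a number 4.3 percentage points lower from compound 3 to compound 4 (within the scatter), and it agrees with the step on the first core: the same change on two cores in this assay, a number 9.9 percentage points lower (within the scatter) from compound 1 to compound 2 and a number 4.3 percentage points lower (within the scatter) from compound 3 to compound 4, 5.6 percentage points apart, within the scatter of two such steps
The methyl step, read on the phenoxymethyl compounds, is a number 3.7 percentage points higher from compound 2 to compound 4 (within the scatter), and it also agrees with its earlier counterpart: the same change on two cores in this assay, a number 1.9 percentage points lower (within the scatter) from compound 1 to compound 3 and a number 3.7 percentage points higher (within the scatter) from compound 2 to compound 4, 5.6 percentage points apart, within the scatter of two such steps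
The change therefore carries across these two cores without a detectable dependence on the core, but every step lies within the scatter, so neither a real effect of the change nor a firm additive rule is shown.

Going by these compounds, whether an amine or a longer chain in place of benzyl or phenoxymethyl would move the inhibition beyond the scatter stays open. So does any dependence on dose, since a single dose is shown.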